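This account rests on a few compounds, and the source may have more. Where it says the series, first, only, none or still open, it means among the compounds named here.

Of the compounds shown here, three sharing one core have been tested in an ADME assay on HEK293-A cells (Homo sapiens) for cytotoxicity, read by MTT assay, with a stated time of 48 h; on this read-out lower numbers stand for stronger inhibition and higher numbers for weaker inhibition. Compound 1 `CC(=O)OC[C@H]1CN(c2ccc(-n3cc(-c4ccccn4)cn3)c(F)c2)C(=O)O1` gives > 400 ug/mL, which is a limit of the assay rather than a number. Compound 2 `O=C1O[C@@H](CSc2cccs2)CN1c1ccc(-n2cc(-c3ccccn3)cn2)c(F)c1` likewise gives > 400 ug/mL, again a limit. The pattern among the values is summarized by the limit of > 400 ug/mL in this assay, at which 2 of the 3 values shown sit. Going by the values given here, compound 3 `CCC(=O)NC[C@H]1CN(c2ccc(-n3cc(-c4ccccn4)cn3)c(F)c2)C(=O)O1` gives 389 ug/mL in this assay, and that is the only actual number among the three. The steps between the measured compounds are accordingly thin: a step that the two limits leave unreadable from compound 1 to compound 2, an at least 1.0-fold lower number from compound 1 to compound 3 (0.01 log units; that floor lies within the scatter) and an at least 1.0-fold lower number from compound 2 to compound 3 (0.01 log units; that floor lies within the scatter). Compound 4 `CNC(=O)[C@H]1CN(c2ccc(-n3cc(-c4ccccn4)cn3)c(F)c2)C(=O)O1` has not yet been measured in this assay. It differs from compound 3 by methylcarbamoyl in place of (propanoylamino)methyl on a saturated ring carbon. None of the three measured steps concerns this ring carbon, all of them concern the saturated chain carbon instead, and none of them is readable beyond the scatter. They therefore give no direction for the move from compound 3 to compound 4. The expected outcome for compound 4 is a 1.0-fold higher number from compound 3 to compound 4 (0.01 log units; within the scatter), that is, no step beyond the scatter. Compound 4 is therefore estimated at 400 ug/mL in this assay, with a range from 200 ug/mL to 800 ug/mL, and with a fair chance that this assay again reports only a limit.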

Compound 4, half-maximal inhibitory concentration: 342 ug/mL
Estimate against measurement, compound 4: 1.2-fold (0.07 log units) above; the range from low to high includes it.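

In this assay, going by these compounds alone, the step at the saturated ring carbon next to the ring oxygen is a 1.1-fold lower number from compound 3 to compound 4 (0.06 log units; within the scatter), the first step with an actual number at both ends. Within the data shown here, it shows that this position accepts methylcarbamoyl, with 4 heavy atoms, in place of (propanoylamino)methyl, with 6 heavy atoms, without a readable shift in this read-out, whereas the earlier steps concerned only the saturated chain carbon and gave no reading at the ring carbon itself. Against the other two compounds, the comparison gives only floors, an at least 1.1-fold lower number from compound 2 to compound 4 (0.06 log units; that floor lies within the scatter) and an at least 1.1-fold lower number from compound 1 to compound 4 (0.06 log units; that floor lies within the scatter), because their values are limits and not numbers: the limit of > 400 ug/mL in this assay, at which 2 of the 4 values shown sit.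

The compounds shown leave open whether a different kind of group on this ring carbon, such as a primary amine or a carboxylic acid, would move the number in this assay beyond the scatter. They also leave open whether a longer chain in place of methylcarbamoyl would do so, since the two groups compared here give values within the scatter of each other.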